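The source may report more compounds than this note shows. Statements on the series, on what has been measured and on what is new or still open speak of the compounds shown alone.

Compound 1 `COc1ccc(Nc2cc(NC(=O)c3ccccc3)ncn2)cc1`: 8880 nM
Compound 2 `O=C(Nc1cc(Nc2ccc(Cl)cc2)ncn1)c1ccc(F)cc1`: > 30000 nM (a limit)

For the measured compounds named here, in a functional assay on NCI-H3255 cells (Homo sapiens) for antiproliferative activity, read by MTT assay, with a stated time of 72 h (a lower number here means a stronger inhibitor, a higher number a weaker inhibitor), compound 1 gives 8880 nM, the only actual number so far. Compound 2 reports only a limit of the assay, > 30000 nM.

Compound 3 `CCOc1ccc(Nc2cc(NC(=O)c3ccccc3)ncn2)cc1` has not yet been measured. It departs from compound 1 by one change: methyl in place of hydrogen on a saturated chain carbon bound to an oxygen on an aromatic ring, which turns methoxy to ethoxy. Going by the values given here, no measured pair shows the size of this change. With only compound 1 at 8880 nM as an anchor, no step beyond the scatter is expected in this assay, in either direction. The estimated 1.1-fold higher number from compound 1 to compound 3 (0.05 log units; within the scatter) is therefore small. For compound 3 the expected value is 10000 nM, with an estimated range of 4000 nM to 25000 nM.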

Compound 3, half-maximal inhibitory concentration: 9170 nM
Beside the measured number, compound 3's estimate is 1.1-fold (0.04 log units) above it, and the stated range covers the measured number.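

In this assay, for the compounds shown here, methyl in place of hydrogen on a saturated chain carbon bound to an oxygen on an aromatic ring gives a 1.0-fold higher number from compound 1 to compound 3 (0.01 log units; within the scatter) as the first measured step at this position. Methoxy and ethoxy therefore cannot be told apart in this read-out, and this one added methyl leaves the number of the shared core unchanged within the scatter. Nothing at hand bears on the reason for so small a step.

From the compounds shown here alone, whether a longer chain such as propoxy, or an amine at the end of the chain, would also leave the number in place stays open. Compound 2 gives only a limit of the assay, > 30000 nM and not a number, and it differs from compound 1 in more than one place, so the effect of its chloro and fluoro groups remains unresolved.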